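Replacing 4-methylphenyl with methyl

The source may hold more compounds than are shown below. What is called first, only, known or untested is meant among the compounds shown, and "the series" means these compounds.

In a functional assay on the whole organism (strain Swiss CD-1) with Mus musculus as the target, with a stated time of 2 h (a higher number here means that more compound is needed for the effect, a lower number that less compound is needed), compound 1 `COCC(C(=O)N1CCN(c2ccc(Cl)cc2)CC1)N1C(=O)CCC1=O` gives 45.5 mg/kg, while compound 2 `COCC(C(=O)N1CCN(c2ccc(C)cc2)CC1)N1C(=O)CCC1=O` gives 21.1 mg/kg as the lower of the two numbers. Among the measured compounds shown here, the only measured step is a 2.2-fold lower number from compound 1 to compound 2 (0.33 log units; beyond the scatter) with methyl in place of chloro on an aromatic carbon. Compound 3 `COCC(C(=O)N1CCN(C)CC1)N1C(=O)CCC1=O` has methyl in place of 4-methylphenyl on an amine nitrogen in a ring. That modest step concerns a substituent on the aromatic ring that compound 3 lacks, so it is a weak guide. A larger step is expected, tentatively toward a higher number, and the estimated change is a 2.8-fold higher number from compound 2 to compound 3 (0.45 log units; beyond the scatter) in this direction. Compound 3 is estimated at 60 mg/kg with an expected range from 18 mg/kg to 200 mg/kg overall.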

Compound 3, dose for half-maximal effect: 68.2 mg/kg
The estimate for compound 3 lay 1.1-fold (0.06 log units) below the measured number, within the range that was stated.
By their numbers in this assay, from the lowest: compound 2; then compounds 1 and 3 (each within the scatter of the next).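

At the amine nitrogen in a ring, the aromatic group is not required for activity in this assay, but what its removal costs depends on which group leaves. Methyl in place of 4-methylphenyl gives a 3.2-fold higher number from compound 2 to compound 3 (0.51 log units; beyond the scatter), whereas methyl in place of 4-chlorophenyl gives a 1.5-fold higher number from compound 1 to compound 3 (0.18 log units; within the scatter), so only the 4-methylphenyl group shows an advantage over methyl. No evidence here accounts for this difference. Still open, on these data alone, is how a hydrogen or a benzyl group on this nitrogen would compare, and whether an unsubstituted phenyl or a 4-methoxyphenyl group would give a lower number than compound 2.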